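The source may hold more compounds than are shown below. What is called first, only, known or untested is meant among the compounds shown, and "the series" means these compounds.

Compound 2 `Cc1c(COc2cccc(OCC3CCOCC3)c2)[nH]c2ccc(Cl)cc2c1=O` holds the lowest number of the three in a functional assay on HUVEC cells (Homo sapiens) for inhibition, using NADPH, with a stated time of 2 h (a higher number here means a weaker inhibitor, a lower number a stronger inhibitor), at 5 nM. Compound 1 `Cc1c(COc2cc(OCC3CCOCC3)ccn2)[nH]c2ccccc2c1=O` gives 49 nM in this assay, a gap beyond the scatter, and compound 3 `Cc1c(COc2cncc(OCCC(C)(C)O)c2)[nH]c2ccccc2c1=O` gives 330 nM, further away still. Compound 4 `Cc1c(COc2cccc(OCC3CCOCC3)c2)[nH]c2ccccc2c1=O` is the next compound to be run; it differs from compound 2 only by hydrogen in place of chloro on an aromatic carbon. For the measured compounds named here, no measured pair in this set shows what removing this group does, so the expectation rests on the change itself and on the standing of compound 2. A moderate weakening is expected for a 3.0-fold higher number from compound 2 to compound 4 (0.48 log units; beyond the scatter), probably beyond the scatter but not large. Compound 4 is estimated at 15 nM, with a range from 5 nM to 45 nM.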

Compound 4, half-maximal inhibitory concentration: 8.9 nM
Estimate against measurement, compound 4: 1.7-fold (0.23 log units) above, within the range that was stated.
By their numbers in this assay, from the lowest: compounds 2 and 4 (each within the scatter of the next); then compound 1; then compound 3.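

In this assay, a 1.8-fold higher number from compound 2 to compound 4 (0.25 log units; within the scatter) stays within the scatter, so hydrogen in place of chloro on this aromatic carbon, meta to a fused ring and para to a fused ring, gives no readable change. The chloro group is therefore not required for the low number of compound 2 on this core. No data here give a reason for this flat step. Open, on these data alone, is whether fluoro, methoxy or nitrile on this carbon would move the number, and whether the chloro step reads the same with the side chains of compound 1 or compound 3.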